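The source may report more compounds than this note shows. Statements on the series, on what has been measured and on what is new or still open speak of the compounds shown alone.

Compound 1 `COc1cc(CNC(=O)/C=C/c2ccccc2O)ccc1O`: 9760 nM in a functional assay on SH-SY5Y cells (Homo sapiens) for cytotoxicity, read by MTT assay, with stated times of 24 h and 4 h; a higher number here means that more compound is needed for the effect, a lower number that less compound is needed.
Compound 2 `COc1cc(/C=C/C(=O)NCc2ccc(OCc3nc(C)c(C)nc3C)c(OC)c2)ccc1O`: 13400 nM in this assay.

On these two numbers compound 2 sits beside compound 1: their values lie within the scatter of each other, so neither can be placed ahead of the other. Compound 3 `COc1cc(CNC(=O)/C=C/c2ccc(OC)c(OC)c2OC)ccc1OCc1nc(C)c(C)nc1C` has not yet been measured. It differs from compound 2 in one place: 2,3,4-trimethoxyphenyl in place of 4-hydroxy-3-methoxyphenyl on a double-bonded chain carbon bound to a double-bonded chain carbon. Within the data shown here, no step between measured compounds is available, so nothing here says how this change should move the number in this assay; the step from compound 2 to compound 3 is expected to stay within the scatter. For compound 3 the estimate is 11000 nM, in a range from 4000 nM to 30000 nM, which means an expected 1.2-fold lower number from compound 2 to compound 3 (0.09 log units; within the scatter).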

Compound 3, half-maximal effective concentration: 3840 nM
Compound 3: the middle estimate sits 2.9-fold (0.46 log units) above what was measured; the measured number lies below the stated range.
By their numbers in this assay, from the lowest: compound 3; then compounds 1 and 2 (each within the scatter of the next).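

In this assay, among these compounds, 2,3,4-trimethoxyphenyl in place of 4-hydroxy-3-methoxyphenyl on a double-bonded chain carbon bound to a double-bonded chain carbon gives a 3.5-fold lower number from compound 2 to compound 3 (0.54 log units; beyond the scatter), the only step available here. It shows that this place can move the number beyond the scatter, which compound 1 and compound 2 alone could not show. No measurement shown explains the step. Going by these compounds, it remains open whether the loss of the hydroxy group or the gain of the methoxy groups accounts for the step, and how an amine or a carboxylic acid on this ring would compare.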